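The source may hold more compounds than are shown below. What is called first, only, known or untested is meant among the compounds shown, and "the series" means these compounds.

Compound 1 `COc1cc(-c2nn(-c3cccc(NC(=O)c4cccc(C(F)(F)F)c4)c3)cc2-c2ccncc2)ccc1Cl` and compound 2 `COc1cc(-c2nn(-c3cccc(NC(=O)Nc4cccc(C(F)(F)F)c4)c3)cc2-c2ccncc2)ccc1Cl` share one core and differ only in the group on the carbonyl carbon. In a functional assay on RPMI-8226 cells (Homo sapiens) for inhibition, read by sulforhodamine B assay, with a stated time of 48 h (a lower number here means a stronger inhibitor of growth, a higher number a weaker inhibitor of growth), compound 1 gives 1570 nM, and compound 2 gives 340 nM. The difference amounts to a 4.6-fold lower number from compound 1 to compound 2 (0.66 log units; beyond the scatter). Compound 2 thus holds the lowest number of the two measured. Compound 3 `COc1cc(-c2nn(-c3cccc(NC(=O)Nc4ccc(Cl)c(C(F)(F)F)c4)c3)cc2-c2ccncc2)ccc1Cl` differs from compound 2 by chloro in place of hydrogen on an aromatic carbon. For the measured compounds named here, no measured step touches that ring, so the step from compound 1 to compound 2 offers no direct guide. A small change, near the scatter, is expected, a 1.4-fold lower number from compound 2 to compound 3 (0.13 log units; within the scatter). Compound 3 is therefore estimated at 250 nM, between 80 nM and 900 nM.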

Compound 3, concentration for 50% growth inhibition: 868 nM
For compound 3 the middle estimate is 3.5-fold (0.54 log units) below the measured one; measured number inside the range.
By their numbers in this assay, from the lowest: compound 2; then compounds 3 and 1 (each within the scatter of the next).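

Putting chloro on the aromatic ring, ortho to the trifluoromethyl group, gives a 2.6-fold higher number from compound 2 to compound 3 (0.41 log units; beyond the scatter) in this assay, so this added atom weakens growth inhibition rather than leaving it unchanged. Set against compound 1, the result is a 1.8-fold lower number from compound 1 to compound 3 (0.26 log units; within the scatter), so the clear advantage compound 2 held over compound 1 is not kept once chloro is present. No evidence is available to explain this loss. Chloro is the only group shown at this position, so whether fluoro, a methyl group or an amine would be tolerated remains open.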